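Tert-butyl for methyl at the weak end of the series

This account rests on a few compounds, and the source may have more. Where it says the series, first, only, none or still open, it means among the compounds named here.

In a functional assay on HeLa cells (Homo sapiens) for cytotoxicity, read by MTT assay, with a stated time of 48 h (on this read-out lower numbers stand for stronger inhibition and higher numbers for weaker inhibition), compound 1 (`Cc1ccc(Cn2cc(COc3ccc4c(=O)ccoc4c3)nn2)cc1`) gives > 100000 nM, which is a limit of the assay and not a number. The position of compound 1 is therefore (the limit of > 100000 nM in this assay, at which 1 of the 2 values shown sits). Compound 2 (`O=c1ccoc2cc(OCc3cn(Cc4ccc(Cl)cc4Cl)nn3)ccc12`) gives 80600 nM in this assay.

For the measured compounds named here, the one measured step is an at least 1.2-fold lower number from compound 1 to compound 2 (0.09 log units; that floor lies within the scatter). It places 2,4-dichlorophenyl in place of 4-methylphenyl on a saturated chain carbon bound to an aromatic nitrogen. From the compounds shown here alone, its true size stays open, since only a floor is known.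

Compound 3 (`CC(C)(C)c1ccc(Cn2cc(COc3ccc4c(=O)ccoc4c3)nn2)cc1`) has tert-butyl in place of methyl on an aromatic carbon, para to a large group: tert-butyl in place of methyl on an aromatic carbon.

Going by the values given here, the only guide is the change in compound 2, where an at least 1.2-fold lower number from compound 1 to compound 2 (0.09 log units; that floor lies within the scatter) gives no firm evidence of a real shift. No step beyond the scatter is therefore expected in this assay, and any movement would most likely be towards a slightly lower number. The expected step is an at least 1.1-fold lower number from compound 1 to compound 3 (0.04 log units; that floor lies within the scatter). The estimate for compound 3 is 90000 nM, with an expected range of 40000 nM to 200000 nM.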

Compound 3, half-maximal inhibitory concentration: 17600 nM
For compound 3 the middle estimate is 5.1-fold (0.71 log units) above the measured one; the whole stated range lies above it.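

In this assay, the substituent on this aromatic carbon, para to a large group, can move the read-out: tert-butyl in place of methyl gives an at least 5.6-fold lower number from compound 1 to compound 3 (0.75 log units; beyond the scatter), which is beyond the scatter. For the compounds shown here, the earlier change on the same aromatic ring, an at least 1.2-fold lower number from compound 1 to compound 2 (0.09 log units; that floor lies within the scatter), offered only a floor within the scatter, so this is the first step that shows a real shift from the weak end. From the compounds shown here alone, its true size remains open, since the value for compound 1 is a limit of the assay and not a number: the limit of > 100000 nM in this assay, at which 1 of the 3 values shown sits.

Whether the lower number belongs to tert-butyl alone or builds gradually from methyl stays open, as ethyl and isopropyl lie outside the compounds shown. Also open, going by these compounds, is whether an amine or a carboxylic acid on the same aromatic carbon would keep the lower number, and whether the tert-butyl step would hold on a ring that also carries chlorine.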